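A few compounds are considered here, and "the series" means these few. Any claim that something is new, unique, unknown or untested is made for them only; others in the source may bear on it.

In a physicochemical assay for lipophilicity, using the shake flask method (a higher number here means a more lipophilic compound, a lower number a more polar compound), compound 1 (`Nc1ncnc(Oc2ccc(NC(=O)C3(C(=O)Nc4ccc(F)cc4)CC3)cc2F)c1/C=N/OCCCO`) gives 2.67 and compound 2 (`CC(O)CO/N=C/c1c(N)ncnc1Oc1ccc(NC(=O)C2(C(=O)Nc3ccc(F)cc3)CC2)cc1F`) gives 2.75, so the two stand level within the scatter. Compound 3 (`COCCCO/N=C/c1c(N)ncnc1Oc1ccc(NC(=O)C2(C(=O)Nc3ccc(F)cc3)CC2)cc1F`) carries 2-methoxyethyl in place of 1-hydroxyethyl on a saturated chain carbon bound to an oxygen on an unsaturated carbon. For the measured compounds named here, the only measured step, a number 0.08 log units higher from compound 1 to compound 2 (within the scatter), exchanges 2-hydroxyethyl for 1-hydroxyethyl, and no measured step covers a change to 2-methoxyethyl, so it is a weak guide. An upward move beyond the scatter in this assay is nevertheless expected, with an estimated step of a number 0.45 log units higher from compound 2 to compound 3 (beyond the scatter). For compound 3 the estimated value is 3.2, with an expected range of 2.85 to 3.6.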

Compound 3, partition coefficient: 3.18
Compound 3: the middle estimate sits 0.02 log units above what was measured; the measured number falls inside the stated range.
By their numbers in this assay, from the lowest: compounds 1 and 2 (each within the scatter of the next); then compound 3.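

Unlike the earlier pair, where moving the hydroxyl left the number within the scatter, this position now shows a real response in this assay: 2-methoxyethyl in place of 1-hydroxyethyl gives a number 0.43 log units higher from compound 2 to compound 3 (beyond the scatter), with one hydrogen-bond donor fewer. Methyl in place of hydrogen on the oxygen gives a number 0.51 log units higher from compound 1 to compound 3 (beyond the scatter), so capping that oxygen counts for more here than the earlier change did. Nothing available explains the rise. As far as these compounds go, whether an amine, a carboxylic acid or a longer chain at this position would shift the number further remains open.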